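This account rests on a few compounds, and the source may have more. Where it says the series, first, only, none or still open, it means among the compounds named here.

Compound 3 `CN(C)CCn1cnnc1-c1cc(Oc2ccc(NC(=O)N/N=C/c3ccc(O)c(O)c3)cc2F)ccn1` carries a 3,4-dihydroxyphenyl group on the carbon with a double bond to nitrogen. In an ADME assay on WI-38 cells (Homo sapiens) for cytotoxicity, read by MTT assay, with a stated time of 72 h (a lower number here means a stronger inhibitor, a higher number a weaker inhibitor), compound 3 gives "not determined" (no result reported), and compound 2 `COc1cc(/C=N/NC(=O)Nc2ccc(Oc3ccnc(-c4nncn4CCN(C)C)c3)c(F)c2)cc(OC)c1OC` likewise gives "not determined" (no result reported). Compound 1 `CN(C)CCn1cnnc1-c1cc(Oc2ccc(NC(=O)N/N=C/c3ccc(F)cc3F)cc2F)ccn1` is the only one of the three with a result: in this assay compound 1 gives 5030 nM. Compound 4 `CN(C)CCn1cnnc1-c1cc(Oc2ccc(NC(=O)N/N=C/c3ccc(F)cc3Cl)cc2F)ccn1` differs from compound 3 in one place: 2-chloro-4-fluorophenyl in place of 3,4-dihydroxyphenyl on a carbon with a double bond to nitrogen. For the measured compounds named here, no measured pair shows how such a change moves the read-out, so for the step from compound 3 to compound 4 in this assay no size or direction can be claimed beyond the scatter. Compound 1, whose ring at this place also carries halogens, gave 5030 nM, and that guides the guess. Compound 4 is therefore expected to give about 5000 nM in this assay, within 2000 nM to 15000 nM.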

Compound 4, half-maximal inhibitory concentration: 2090 nM
Compound 4: the middle estimate sits 2.4-fold (0.38 log units) above what was measured; low and high end bracket the measured number.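

In this assay, chloro in place of fluoro on an aromatic carbon gives a 2.4-fold lower number from compound 1 to compound 4 (0.38 log units; beyond the scatter) as a modest change beyond the usual scatter. For the compounds shown here, this is the first readable step at this ring, and it shows that swapping one halogen is enough to move the number. Steps involving compound 2 or compound 3 cannot be read, as neither has a result.

On these data alone, how a bromo group or an amine on the same aromatic carbon would move the number remains open. No measurement shown offers a cause for this step.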